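The source may hold more compounds than are shown below. What is called first, only, known or untested is meant among the compounds shown, and "the series" means these compounds.

- compound 1 `Cc1ccc2c(c1C)CN(C(=O)N(C)C)CC2c1cccc(O)c1`: 376 nM
- compound 2 `Cc1ccc2c(c1C)CN(C(=O)N(C)C)C[C@@H]2c1cccc(O)c1`: 234 nM

Going by the values given here, these two values come from a functional assay on A2780 cells (Homo sapiens) for antiproliferative activity (a higher number here means a weaker inhibitor, a lower number a stronger inhibitor), and lie within the scatter of each other: a 1.6-fold lower number from compound 1 to compound 2 (0.21 log units; within the scatter) is too small to rank them, so compound 1 stands level with the only other measured compound. That step concerns only the fact that one of compounds 1 and 2 is drawn with a defined configuration and the other without, at the place where they differ and leaves the substituent on the aromatic ring untouched.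

The next compound, compound 3 `Cc1ccc2c(c1C)CN(C(=O)N(C)C)CC2c1cccc(Cl)c1`, has not been measured. It carries chloro in place of hydroxy on an aromatic carbon, meta to a large group: chloro in place of hydroxy on an aromatic carbon. Among the compounds with values here, no measured step covers such a swap, so the data point in no direction and the expectation must stay broad. The expected change, a 1.2-fold higher number from compound 1 to compound 3 (0.08 log units; within the scatter), is an estimate that stays within the scatter. For compound 3 the estimated value is 450 nM with an expected range from 110 nM to 2000 nM for now.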

Compound 3, half-maximal inhibitory concentration: 3020 nM
Beside the measured number, compound 3's estimate is 6.7-fold (0.83 log units) below it; measured number above the stated range.
By their numbers in this assay, from the lowest: compounds 2 and 1 (each within the scatter of the next); then compound 3.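

In this assay, the aromatic substituent turns out to matter, which the earlier comparison could not show because it left this group untouched. Going from 3-hydroxyphenyl to 3-chlorophenyl gives an 8.0-fold higher number from compound 1 to compound 3 (0.90 log units; beyond the scatter) so here a single heavy atom on the aromatic ring separates a stronger inhibitor from a clearly weaker one. The swap also takes away the hydrogen-bond donor and acceptor counted for hydroxy, but nothing measured here links either loss, or any other feature of the swap, to the rise in the number.

One replacement cannot show what this position tolerates: an amino group, a methoxy group or a carboxylic acid in the same place could each point in a different direction. Going by these compounds, it also remains open whether chloro in place of hydroxy has a similar effect on the defined configuration of compound 2.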